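From trifluoromethoxy to nitro: notes on compound 3

The compounds below may be only part of what the source reports. "The series", "measured", "known", "first", "only" and "open" are said of these compounds alone.

In an ADME assay on MDCK cells (Canis lupus familiaris) for cytotoxicity, read by MTT assay, with a stated time of 48 h (on this read-out higher numbers stand for lower toxicity in this test and lower numbers for higher toxicity in this test), compound 1 (`ClC1=C(Cn2cc(-c3ccc(Cl)c(Cl)c3)nn2)CCc2nc(-c3cccs3)ccc21`) gives > 300 ug/mL, which is a limit and not a number. Compound 2 (`FC(F)(F)Oc1ccc(-c2cn(CC3=C(Cl)c4ccc(-c5cccs5)nc4CC3)nn2)cc1`) gives > 300 ug/mL, likewise only a limit. The series therefore stands at the limit of > 300 ug/mL in this assay, at which 2 of the 2 values shown sit, and compound 2 has no exact value.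

Compound 3 (`O=[N+]([O-])c1ccc(-c2cn(CC3=C(Cl)c4ccc(-c5cccs5)nc4CC3)nn2)cc1`) carries nitro in place of trifluoromethoxy on an aromatic carbon, para to a large group: nitro in place of trifluoromethoxy on an aromatic carbon.

Going by the values given here, the one measured step is a step that the two limits leave unreadable from compound 1 to compound 2, with 4-(trifluoromethoxy)phenyl in place of 3,4-dichlorophenyl on an aromatic carbon. Among the compounds with values here, that step yields no size to carry forward, and no measured step covers nitro. The expectation rests on compound 2 and its limit of > 300 ug/mL.

The step expected in this assay is a number no higher from compound 2 to compound 3 (the limit leaves the size open), with no size beyond the scatter and no direction anticipated. Another limit is the more likely report for compound 3. If a number is returned, the estimate for compound 3 is 300 ug/mL, with an expected range from 120 ug/mL to 500 ug/mL.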

Compound 3, half-maximal cytotoxic concentration: 40 ug/mL
Compound 3: middle estimate off by 7.5-fold (0.88 log units), on the high side, and the stated range ends above it.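

In this assay, the place para to a large group turns out not to be silent: nitro in place of trifluoromethoxy gives an at least 7.5-fold lower number from compound 2 to compound 3 (0.87 log units; beyond the scatter), and a lower number here stands for higher toxicity in this test. The comparison with the dichlorinated compound points the same way, with 4-nitrophenyl in place of 3,4-dichlorophenyl giving an at least 7.5-fold lower number from compound 1 to compound 3 (0.87 log units; beyond the scatter), whereas the step between the two earlier compounds cannot be read. Compound 3 is thus the first compound shown with a number rather than a limit, and the series no longer sits wholly at one ceiling: the limit of > 300 ug/mL in this assay, at which 2 of the 3 values shown sit.

As far as these compounds go, both steps give only a minimum size, and the full size of the change stays unknown while the values of compound 1 and compound 2 remain limits and not numbers. Also open, from the compounds shown here alone, is whether the lower number is particular to nitro or would also appear with a nitrile, an amine or a carboxylic acid at the same place on the ring, and whether it would hold with the substituents on the rest of the shared core changed.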